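Saturating the cyanovinyl arm of compound 1

This account rests on a few compounds, and the source may have more. Where it says the series, first, only, none or still open, it means among the compounds named here.

Measured compounds in an in vitro ADME assay on microsomes from liver (Homo sapiens) for metabolic stability, tested at 1 uM; on this read-out lower numbers stand for slow clearance and higher numbers for fast clearance:
compound 1, `COC(=O)c1cc(N)c(Nc2ccc(C#N)cc2)cc1Oc1c(C)cc(/C=C/C#N)cc1C`: 20 mL.min-1.g-1
compound 2, `Cc1cc(/C=C/C#N)cc(C)c1Oc1cc(Nc2ccc(C#N)cc2)c(N)cc1CO`: 230 mL.min-1.g-1
compound 3, `Cc1cc(/C=C/C#N)cc(C)c1Oc1cc(Nc2ccc(C#N)cc2)c(N)cc1[N+](=O)[O-]`: 150 mL.min-1.g-1

Compound 1 stands lowest of the three in this assay; the steps to the others, a 12-fold higher number from compound 1 to compound 2 (1.06 log units; beyond the scatter) and a 7.5-fold higher number from compound 1 to compound 3 (0.88 log units; beyond the scatter), are both beyond the scatter, while the pair of compound 2 and compound 3 shows a 1.5-fold lower number from compound 2 to compound 3 (0.19 log units; within the scatter) and is within it.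

Compound 4, `COC(=O)c1cc(N)c(Nc2ccc(C#N)cc2)cc1Oc1c(C)cc(CCC#N)cc1C`, differs from compound 1 at one place: 2-cyanoethyl in place of 2-cyanoethenyl on an aromatic carbon. For the measured compounds named here, none of the measured steps bears on this position. All three alter the methoxycarbonyl site of the shared core, and no pair shown differs in the 2-cyanoethenyl arm. Going by the values given here, the change to compound 4 therefore has no measured precedent, and the expectation rests on compound 1 alone: the expected step is a 1.5-fold higher number from compound 1 to compound 4 (0.18 log units; within the scatter), that is none beyond the scatter, with a wide range allowed. Compound 4 is estimated at 30 mL.min-1.g-1 in this assay, between 12 mL.min-1.g-1 and 80 mL.min-1.g-1.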

Compound 4, intrinsic clearance in microsomes: 40 mL.min-1.g-1
Compound 4: middle estimate off by 1.3-fold (0.12 log units), on the low side; the range from low to high includes it.
By their numbers in this assay, from the lowest: compounds 1 and 4 (each within the scatter of the next); then compounds 3 and 2 (each within the scatter of the next).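

Replacing 2-cyanoethenyl with 2-cyanoethyl gives a 2.0-fold higher number from compound 1 to compound 4 (0.30 log units; within the scatter) in this assay. This is the first step shown away from the methoxycarbonyl site, and on this read-out it does not separate the two compounds, so with methoxycarbonyl in place the double bond of the arm can go without a step beyond the scatter, unlike the change at that site in a 12-fold higher number from compound 1 to compound 2 (1.06 log units; beyond the scatter). No measurement at hand accounts for this result.

Open, as far as these compounds go, is whether 2-cyanoethyl reads the same way with hydroxymethyl or nitro in place of methoxycarbonyl, as in compound 2 and compound 3. Also open, from the compounds shown here alone, is how an amine, a carboxylic acid or a longer chain in place of 2-cyanoethyl would read in this assay on the core of compound 1.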